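The source may report more compounds than this note shows. Statements on the series, on what has been measured and on what is new or still open speak of the compounds shown alone.

In a functional assay on HCT-15 cells (Homo sapiens) for cytotoxicity, read by ELISA, with a stated time of 2 days (on this read-out higher numbers stand for weaker inhibition and lower numbers for stronger inhibition), compound 1 (`Oc1cccc(-c2cc(-c3ccccc3)cc(-c3ccco3)n2)c1`) gives 13500 nM and compound 2 (`Oc1ccc(-c2cc(-c3ccccc3)cc(-c3cccs3)n2)cc1`) gives 12500 nM. Going by the values given here, these two values lie within the usual scatter of repeated measurements, so compound 2 stands level with compound 1 on the numbers so far.

Compound 3 (`Oc1ccc(-c2cc(-c3ccccc3)cc(-c3ccco3)n2)cc1`) has not yet been measured in this assay. It departs from compound 2 in one place: furan-2-yl in place of thiophen-2-yl on an aromatic carbon, next to the ring nitrogen (furan-2-yl in place of thiophen-2-yl on an aromatic carbon). Both groups are five-membered aromatic rings with 1 hetero atom, and the swap exchanges sulfur for oxygen in that ring.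

Among the compounds with values here, no pair of measured compounds shows this change on its own, so the data give no direct size for it. The expectation rests on compound 1, which also carries furan-2-yl and gives 13500 nM, a number level with that of compound 2. No shift beyond the scatter is expected in either direction. The expected change is small: a 1.0-fold lower number from compound 2 to compound 3 (0.02 log units; within the scatter). Compound 3 is estimated at 12000 nM, with an expected range from 5000 nM to 26000 nM.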

Compound 3, half-maximal inhibitory concentration: 3500 nM
For compound 3 the middle estimate is 3.4-fold (0.54 log units) above the measured one; measured number below the stated range.
By their numbers in this assay, from the lowest: compound 3; then compounds 2 and 1 (each within the scatter of the next).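

In this assay, furan-2-yl in place of thiophen-2-yl on the aromatic carbon next to the ring nitrogen proves to be far from a neutral exchange of oxygen for sulfur: with the 4-hydroxyphenyl group unchanged, the swap gives a 3.6-fold lower number from compound 2 to compound 3 (0.55 log units; beyond the scatter). The other listed change also counts on its own: with furan-2-yl unchanged, 4-hydroxyphenyl in place of 3-hydroxyphenyl gives a 3.9-fold lower number from compound 1 to compound 3 (0.59 log units; beyond the scatter). Compound 1 and compound 2 differ from each other in both of these places, so their level numbers could not reveal either step, and each step becomes visible only through compound 3, which differs from each of them in just one place.

The data offer no measurement that explains why either change moves the number. From the compounds shown here alone, it also remains open how this position would respond to a non-aromatic group such as a propyl chain or to a ring with more hetero atoms such as thiazol-2-yl, and how the series would read with an amine or a carboxylic acid in place of the hydroxyl group.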